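Compound 3: furan-3-yl on the shared core

This account rests on a few compounds, and the source may have more. Where it says the series, first, only, none or still open, it means among the compounds named here.

In an ADME assay on cells (Homo sapiens) for cytotoxicity, read by resazurin assay, with a stated time of 5 days (a higher number here means that more compound is tolerated, a lower number that less compound is tolerated), compound 1 (`COc1ccc(-c2nc(CS(=O)(=O)c3cccc(Cl)c3)nc3ccsc23)cc1`) gives 69000 nM. Compound 2 (`O=S(=O)(Cc1nc(-c2ccc(F)nc2)c2sccc2n1)c1cccc(Cl)c1`) gives 40000 nM, so the two numbers lie within the scatter of each other and neither stands apart.

Compound 3 (`O=S(=O)(Cc1nc(-c2ccoc2)c2sccc2n1)c1cccc(Cl)c1`) carries furan-3-yl in place of 6-fluoropyridin-3-yl on an aromatic carbon of the shared core: furan-3-yl in place of 6-fluoropyridin-3-yl on an aromatic carbon. Going by the values given here, only one measured step bears on this place, a 1.7-fold lower number from compound 1 to compound 2 (0.24 log units; within the scatter), with 6-fluoropyridin-3-yl in place of 4-methoxyphenyl. A single step of that size gives no direction for this assay, and no five-membered aromatic ring has yet been measured here. No change beyond the scatter is therefore expected, and the estimated step is a 1.1-fold higher number from compound 2 to compound 3 (0.05 log units; within the scatter). For compound 3 the expected value is 45000 nM, with an estimated range from 18000 nM to 100000 nM.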

Compound 3, half-maximal cytotoxic concentration: > 50000 nM
Compound 3 gave a limit, no number; the forecaster's own chance of this, stated with the estimate: 15%; at least 1.1-fold (0.04 log units) between middle value and limit.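

In this assay, compound 3 is the first compound shown with a five-membered aromatic ring at this position, and it gives > 50000 nM, which is a limit and not a number. The step is an at least 1.2-fold higher number from compound 2 to compound 3 (0.09 log units; that floor lies within the scatter), so a five-membered aromatic ring in place of a six-membered one brings no lower number here, though no rise beyond the scatter can be claimed either. The step from compound 1 to compound 3 cannot be read, and any true difference from compound 2 stays hidden as well: the limit of > 50000 nM in this assay, at which 1 of the 3 values shown sits.

From the compounds shown here alone, how far the true number of compound 3 lies from its limit remains open. So does the response of this position to a group without an aromatic ring, such as an amine or a carboxylic acid.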